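The compounds below may be only part of what the source reports. "The series", "measured", "known", "first", "only" and "open" are said of these compounds alone.

The measured compounds and their readings:

compound 1, `Oc1ccc(-c2cc(-c3cccs3)nc(-c3ccccc3Cl)c2)cc1`: in an assay on isolated protein for inhibition of DNA topoisomerase 1 (Homo sapiens), with a stated time of 30 min, tested at 100 uM (a higher number here means a stronger effect of the compound at the concentration tested, a lower number a weaker effect), compound 1 gives 2.2%
compound 2, `Oc1cccc(-c2cc(-c3ccsc3)nc(-c3cccc(Cl)c3)c2)c1`: in this assay compound 2 gives 26.2%
compound 3, `Oc1ccc(-c2cc(-c3ccsc3)nc(-c3ccccc3Cl)c2)cc1`: in this assay compound 3 gives 4.1%

Of the three, compound 2 stands highest in this assay, and its gaps to compound 3 and to compound 1 both lie beyond the scatter. Compound 1 and compound 3 share a core and differ only in thiophen-2-yl in place of thiophen-3-yl on an aromatic carbon; the step this change made in this assay is a number 1.9 percentage points lower from compound 3 to compound 1 (within the scatter), which is within the scatter. How the core of compound 2 differs from the core of compound 3 is not broken down here.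

Compound 4, `Oc1cccc(-c2cc(-c3cccc(Cl)c3)nc(-c3cccs3)c2)c1`, has not yet been measured. It differs from compound 2 by thiophen-2-yl in place of thiophen-3-yl on an aromatic carbon. For the measured compounds named here, this is the same kind of change as the one from compound 3 to compound 1, but not the same: around the place it sits meta to a 3-chlorophenyl group and meta to a 3-hydroxyphenyl group, whereas in compound 3 and compound 1 it sits meta to a 2-chlorophenyl group and meta to a 4-hydroxyphenyl group.

Going by the values given here, since the one measured instance of this change, a number 1.9 percentage points lower from compound 3 to compound 1 (within the scatter), stayed within the scatter, the step expected in this assay is likewise small, a number 2.2 percentage points lower from compound 2 to compound 4 (within the scatter), with the added uncertainty that the surroundings of the place are not identical. Compound 4 is therefore estimated at 24%, expected to lie between 8% and 40%.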

Compound 4, a percentage reported as inhibition, at one concentration (the size of the read-out at that concentration, not a potency): 7.6%
Compound 4: middle estimate off by 16.4 percentage points, on the high side; the measured number lies below the stated range.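

In this assay, putting thiophen-2-yl in place of thiophen-3-yl on an aromatic carbon gave a number 18.6 percentage points lower from compound 2 to compound 4 (beyond the scatter), a step that lies beyond the scatter and so is not the negligible change seen on the other core. Set beside the earlier pair, this shows that the change does not carry over at a single size from one core to another in this series: the same change on two cores in this assay, a number 1.9 percentage points lower (within the scatter) from compound 3 to compound 1 and a number 18.6 percentage points lower (beyond the scatter) from compound 2 to compound 4, 16.7 percentage points apart, beyond the scatter of two such steps It does not show what sets the size of the step, and it gives no general rule for the series, as there are only two pairs and compound 3 already gives 4.1%, which leaves little room for any fall on that core.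

The compounds shown leave open how the same change would behave on a core carrying the 3-chlorophenyl group together with a 4-hydroxyphenyl group, or a 2-chlorophenyl group together with the 3-hydroxyphenyl group, which would separate the two differences in the surroundings. They also leave open whether the step would hold its size with an amine or a carboxylic acid in place of the hydroxyl group, and how large it would be at any other concentration.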